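Replacing a dinitrophenyl ether in a cytotoxicity series

This account rests on a few compounds, and the source may have more. Where it says the series, first, only, none or still open, it means among the compounds named here.

Measured compounds and their values:
Compound 1 `C=C1C(=O)O[C@@H]2CC(C)=C([C@@H](C)CCCOC(C)=O)[C@@H](OC(=O)CN3CCCC3)[C@H]12` gives 12700 nM in a functional assay on HeLa cells (Homo sapiens) for cytotoxicity, read by sulforhodamine B assay, with a stated time of 72 h; on this read-out lower numbers stand for stronger inhibition and higher numbers for weaker inhibition.
Compound 2 `C=C1C(=O)O[C@@H]2CC(C)=C([C@@H](C)CCCOC(C)=O)[C@@H](OC(=O)CN3CCCCC3)[C@H]12` gives 10300 nM in this assay.
Compound 3 `C=C1C(=O)O[C@@H]2CC(C)=C([C@@H](C)CCCOC(C)=O)[C@@H](OC(=O)COc3ccc([N+](=O)[O-])cc3[N+](=O)[O-])[C@H]12` gives only a limit, > 100000 nM, in this assay.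

Compounds 1 and 2 share the same core and differ only in the amine ring attached to the ester side group; the step of a 1.2-fold lower number from compound 1 to compound 2 (0.09 log units; within the scatter) lies within the scatter, so the two numbers cannot be told apart. Compound 3 carries the 2,4-dinitrophenyl ether on that side group instead of an amine, and for it this assay returns no number, only (the limit of > 100000 nM in this assay, at which 1 of the 3 values shown sits). Among the compounds with values here, compound 3 therefore stands apart from compounds 1 and 2 as the one member without a measured value.

Compound 4 `C=C1C(=O)O[C@@H]2CC(C)=C([C@@H](C)CCCOC(C)=O)[C@@H](OC(=O)COc3ccc4c(CC)noc4c3)[C@H]12` is made from compound 3 by a group of 11 heavy atoms (9 carbon, 1 nitrogen, 1 oxygen; one five-membered aromatic ring with 2 hetero atoms, one six-membered aromatic ring of carbon only) in place of a group of 12 heavy atoms (6 carbon, 2 nitrogen, 4 oxygen; one six-membered aromatic ring of carbon only), on an oxygen on a saturated carbon. Within the data shown here, no measured step touches this oxygen position: the only measured step, between compounds 1 and 2, concerns a different place and was within the scatter, so it gives no guide to direction or size here. Because compound 3 is known only as a limit, the step to compound 4 cannot be anchored to a number, and the expectation must stay wide. Compound 4 is estimated at 40000 nM, with a range from 6000 nM to 150000 nM. That estimate corresponds to an expected step of an at least 2.5-fold lower number from compound 3 to compound 4 (0.39 log units; beyond the scatter).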

Compound 4, half-maximal inhibitory concentration: 21700 nM
The estimate for compound 4 lay 1.8-fold (0.27 log units) above the measured number; low and high end bracket the measured number.
By their numbers in this assay, from the lowest: compounds 2, 1 and 4 (each within the scatter of the next, the first and the last beyond it). At a limit, above all of these: compound 3.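

Placing the new two-ring aromatic group on the oxygen in place of 2,4-dinitrophenyl gives an at least 4.6-fold lower number from compound 3 to compound 4 (0.66 log units; beyond the scatter) in this assay, which shows that an aromatic ether at this position can give a real number. Compound 3 remains a limit rather than a number, so this step has only a minimum size and its true size stays unknown: the limit of > 100000 nM in this assay, at which 1 of the 4 values shown sits.

Set against the ring amines, the result is mixed, with a 2.1-fold higher number from compound 2 to compound 4 (0.32 log units; beyond the scatter) lying beyond the scatter but a 1.7-fold higher number from compound 1 to compound 4 (0.23 log units; within the scatter) lying within it, so a change from a ring amine to this aromatic ether does not separate compound 4 from both amine compounds.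

The new group differs from 2,4-dinitrophenyl in several features at once, including its ring system, its ethyl group and the absence of nitro groups, so the compounds shown cannot say which of these features matters. Going by these compounds, it also remains open how a plain phenyl ether, or an open-chain amine such as diethylamino, would behave at this position.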